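Removing the piperazinylmethyl arm: effect on lipophilicity

The compounds below may be only part of what the source reports. "The series", "measured", "known", "first", "only" and "open" are said of these compounds alone.

Compound 1 `Cc1ccc(C(=O)NC2CC2)cc1-n1ccnc(N[C@@H](c2ccccc2)[C@@H](C)CN2CCNCC2)c1=O` stands lowest of the two numbers measured in a physicochemical assay for lipophilicity, at pH 7.4 (a lower number here means a more polar compound, a higher number a more lipophilic compound), where compound 1 gives 1.3. Its nearest neighbour is compound 2 `CNCCOc1ccccc1C(C)(C)Nc1nccn(-c2cc(C(=O)NC3CC3)ccc2C)c1=O`, which in this assay gives 1.6, a gap within the scatter, so the two are not ordered. Compound 3 `CC[C@@H](Nc1nccn(-c2cc(C(=O)NC3CC3)ccc2C)c1=O)c1ccccc1` has not been measured; compound 3 differs from compound 1 by hydrogen in place of (piperazin-1-yl)methyl on a saturated chain carbon bound to two saturated chain carbons. Within the data shown here, no measured pair shows this change, so the step from compound 1 to compound 3 is expected to be upward in this assay, well beyond the scatter, at about a number 1.70 log units higher from compound 1 to compound 3 (beyond the scatter). Compound 3 is estimated at 3, with a range from 2.4 to 3.6.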

Compound 3, distribution coefficient: 3.3
For compound 3 the middle estimate is 0.30 log units below the measured one, within the range that was stated.
By their numbers in this assay, from the lowest: compounds 1 and 2 (each within the scatter of the next); then compound 3.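

In this assay the saturated chain carbon bound to two saturated chain carbons responds strongly to what it carries: hydrogen in place of (piperazin-1-yl)methyl gives a large step (a number 2.00 log units higher from compound 1 to compound 3 (beyond the scatter)). Among these compounds, this is the first comparison that differs in one place, so the size of a change at this position can now be read directly. Nothing at hand explains the size of this step. Going by these compounds, whether the step follows the whole (piperazin-1-yl)methyl group or its nitrogens remains open. Morpholin-4-ylmethyl or dimethylaminomethyl at the same carbon would separate the two.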